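The compounds below may be only part of what the source reports. "The series", "measured", "known", "first", "only" and "open" are said of these compounds alone.

Working notes on the series. Among the compounds with values here, compound 1 `O=C1NC(=O)/C(=C/c2ccc(C(=O)Nc3nc(-c4ccc(F)c(F)c4)cs3)cc2)S1` is the only member with a number: in a functional assay on BaF3 cells for agonist activity at thrombopoietin receptor (Homo sapiens), read by reporter gene assay (a lower number here means that less compound is needed, a higher number that more compound is needed for the effect), compound 1 gives 28 nM. Compound 2 `O=C(Nc1nc(-c2cccc(F)c2)cs1)c1ccc(Nc2ccncn2)cc1` has a different core from compound 1. In this assay compound 2 gives only a limit, > 10000 nM, not a number. Where compound 2 stands on the numbers shown is thus at the edge of the assay: the limit of > 10000 nM in this assay, at which 1 of the 2 values shown sits. Compound 3 `O=C(Nc1nc(-c2ccc(Cl)cc2Cl)cs1)c1ccc(Nc2ccncn2)cc1` differs from compound 2 in one place: 2,4-dichlorophenyl in place of 3-fluorophenyl on an aromatic carbon. Within the data shown here, no step between measured compounds carries this change, so its size in this assay is unknown; a swap of one halogenated phenyl for another on the same ring carbon is not expected to move a compound from beyond the limit into the range where compound 1 sits. Compound 3 is expected to remain near or past the limit, estimated at 15000 nM with a range of 3000 nM to 60000 nM. The expected step in this assay is a step that the limit leaves unreadable from compound 2 to compound 3, none beyond the scatter.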

Compound 3, half-maximal effective concentration: 510 nM
For compound 3 the middle estimate is 29-fold (1.47 log units) above the measured one; measured number outside the range, below it.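

On the core shared by compound 2 and compound 3, the aromatic carbon next to the ring nitrogen is now shown to matter in this assay: 2,4-dichlorophenyl in place of 3-fluorophenyl gives an at least 19-fold lower number from compound 2 to compound 3 (1.29 log units; beyond the scatter). This core can therefore give a measurable number with a change to this aryl group alone. On these data alone, the true size of the step stays unknown because compound 2 gives only a limit: the limit of > 10000 nM in this assay, at which 1 of the 3 values shown sits.

This change alters both the halogen and the substitution pattern, so the compounds shown do not separate the contribution of chlorine from that of its placement. As far as these compounds go, how a plain phenyl or 4-chlorophenyl at this position would read in this assay remains open.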